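Trifluoromethyl for methyl, tried a second time

This account rests on a few compounds, and the source may have more. Where it says the series, first, only, none or still open, it means among the compounds named here.

Of the compounds shown here, three have been measured in a physicochemical assay for metabolic stability, read by LC-MS, in simulated gastric fluid, with a stated time of 15 min, tested at 50 uM; on this read-out higher numbers stand for a more stable compound and lower numbers for a less stable compound. Compound 1 `Cc1ccccc1OC(=O)c1coc(-c2ccccc2)n1` gives 1.5%, and compound 2 `O=C(Oc1ccccc1C(F)(F)F)c1coc(-c2ccccc2)n1` gives 1.2%. The two differ in one place, (trifluoromethyl in place of methyl on an aromatic carbon), and that change gives a number 0.3 percentage points lower from compound 1 to compound 2 (within the scatter). Compound 3 `Cc1ccccc1COC(=O)c1coc(-c2ccccc2)n1` gives 3.1% in this assay; how its core differs from that of compound 1 is not broken down here. Compound 4 `O=C(OCc1ccccc1C(F)(F)F)c1coc(-c2ccccc2)n1` has not yet been measured. It differs from compound 3 by trifluoromethyl in place of methyl on an aromatic carbon, the same change as that from compound 1 to compound 2, made here on the core of compound 3. The step from compound 3 to compound 4 is expected to be a number 0.6 percentage points lower from compound 3 to compound 4 (within the scatter), a step as small as the earlier one, because a number 0.3 percentage points lower from compound 1 to compound 2 (within the scatter) is within the scatter. Compound 4 is therefore estimated at 2.5%.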

Compound 4, percent of the compound remaining: 0.8%
Estimate against measurement, compound 4: 1.7 percentage points above; the range from low to high includes it.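

In this assay, trifluoromethyl in place of methyl on an aromatic carbon gives a number 2.3 percentage points lower from compound 3 to compound 4 (within the scatter) and, on the other core, a number 0.3 percentage points lower from compound 1 to compound 2 (within the scatter). On both cores, then, the change cannot be told apart from repeated-measurement scatter, but that does not show that it has no effect or that the two cores respond alike. Nothing available here speaks to the reason for these numbers. From the compounds shown here alone, whether an amine or a carboxylic acid on that aromatic carbon would give a step beyond the scatter remains open. So does whether the same change would behave alike with an amide in place of the ester.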